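A Fluoro Step Carried onto a Second Core

This account rests on a few compounds, and the source may have more. Where it says the series, first, only, none or still open, it means among the compounds named here.

Three compounds have been measured in a functional assay on HCT-116 cells (Homo sapiens) for antiproliferative activity, read by CellTiter-Glo, with a stated time of 72 h; on this read-out lower numbers stand for stronger inhibition and higher numbers for weaker inhibition:
Compound 1 `Cc1ccc(-c2cc(/C=C/c3ccc(C(=O)NO)cc3)ccn2)cc1` gives 2390 nM.
Compound 2 `Cc1ccc(-c2cc(/C=C/c3ccc(C(=O)NO)cc3)ccn2)c(F)c1` gives 800 nM.
Compound 3 `Cc1ccc(-c2cncc(/C=C/c3ccc(C(=O)NO)cc3)c2)cc1` reports only a limit of the assay, > 10000 nM.

Compound 1 and compound 2 share one core and differ by fluoro in place of hydrogen on an aromatic carbon. That change produced a 3.0-fold lower number from compound 1 to compound 2 (0.48 log units; beyond the scatter). Compound 3 is built on another core; the difference between the two cores is not broken down here. Compound 4 `Cc1ccc(-c2cncc(/C=C/c3ccc(C(=O)NO)cc3)c2)c(F)c1`, not yet measured, differs from compound 3 by fluoro in place of hydrogen on an aromatic carbon, the same change as that between compound 1 and compound 2, at a place described in identical words. For compound 3 only the limit of > 10000 nM in this assay, at which 1 of the 3 values shown sits, is known, so any expectation for compound 4 rests on the earlier step applied to a starting point that is itself a limit. Compound 4 is therefore expected to give 7000 nM, somewhere between 2500 nM and 20000 nM. That would correspond to an expected step of an at least 1.4-fold lower number from compound 3 to compound 4 (0.15 log units; that floor lies within the scatter).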

Compound 4, half-maximal inhibitory concentration: 2990 nM
Beside the measured number, compound 4's estimate is 2.3-fold (0.37 log units) above it, within the range that was stated.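

In this assay, fluoro in place of hydrogen on the core of compound 3 gave an at least 3.3-fold lower number from compound 3 to compound 4 (0.52 log units; beyond the scatter). The change thus went the same way on both cores in these two pairs, but this does not show that its size is the same: the same change on two cores in this assay, a 3.0-fold lower number (0.48 log units; beyond the scatter) from compound 1 to compound 2 and an at least 3.3-fold lower number (0.52 log units; beyond the scatter) from compound 3 to compound 4; the limit leaves it open whether they differ. On these data alone, compound 3 reports only a limit, so the step on this core is a lower bound and its true size stays unknown: the limit of > 10000 nM in this assay, at which 1 of the 4 values shown sits.

The compounds shown leave open whether chloro or a methoxy group at the same place would give a step like that of fluoro on either core. They also leave open whether the fluoro step would hold with an amine in place of the methyl group.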